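Replacing a Thiazolyl Amide With a Saturated Ring in Liver Cells

The source may hold more compounds than are shown below. What is called first, only, known or untested is meant among the compounds shown, and "the series" means these compounds.

In a toxicity assay on HepG2 cells (Homo sapiens) for inhibition, read by CellTiter-Glo, with a stated time of 48 h (on this read-out higher numbers stand for weaker inhibition and lower numbers for stronger inhibition), compound 1 `COc1ccc2nc(C)cc(OCC(=O)Nc3ccccc3)c2c1` gives 39800 nM. For compound 2 `COc1ccc2nc(C)cc(OCC(=O)Nc3nccs3)c2c1` this assay reports only a limit, > 100000 nM. Compound 2 therefore rests at the limit of > 100000 nM in this assay, at which 1 of the 2 values shown sits. The change between them produced an at least 2.5-fold higher number from compound 1 to compound 2 (0.40 log units; beyond the scatter). Compound 3 `COc1ccc2nc(C)cc(OCC(=O)NC3CONC3=O)c2c1` differs from compound 2 by a group of 6 heavy atoms (3 carbon, 1 nitrogen, 2 oxygen; one five-membered non-aromatic ring with 2 hetero atoms) in place of a group of 5 heavy atoms (3 carbon, 1 nitrogen, 1 sulfur; one five-membered aromatic ring with 2 hetero atoms), on an amide-type nitrogen. Among the compounds with values here, no measured step covers this exact change; only the step between compound 1 and compound 2 touches the same nitrogen, and it was at least modest. For compound 3 the number is expected to remain near the limit, estimated at 100000 nM within 40000 nM to 300000 nM. The expected step is a number no higher from compound 2 to compound 3 (the limit leaves the size open), none beyond the scatter.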

Compound 3, half-maximal inhibitory concentration: > 100000 nM
Compound 3 was reported as a limit (the forecaster's own chance of this, stated with the estimate: 65%); the middle value lies on the limit itself.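

Replacing the phenyl of compound 1 with the saturated ring gives an at least 2.5-fold higher number from compound 1 to compound 3 (0.40 log units; beyond the scatter) in this assay, so a second, non-aromatic ring on this amide-type nitrogen also moves the number away from that of compound 1. The step from compound 2 to compound 3 cannot be read. Compound 3, like compound 2, therefore gives only a limit and no number: the limit of > 100000 nM in this assay, at which 2 of the 3 values shown sit.

As far as these compounds go, how far either compound lies past that limit stays open. So does whether a small chain such as ethyl, or a ring carrying a carboxylic acid, on this nitrogen would also reach it.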